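This account rests on a few compounds, and the source may have more. Where it says the series, first, only, none or still open, it means among the compounds named here.

Measured compounds in a functional assay on PANC-1 cells (Homo sapiens) for inhibition, read by MTT assay, with a stated time of 24 h, tested at 10 uM; a lower number here means less inhibition, a higher number more inhibition at the concentration tested (going by the name of the read-out):

Compound 1, `CC(C)=CCC1Cc2c(OCCCNS(=O)(=O)c3ccc(Cl)cc3)cc(=O)n(CCCO)c2CC1(C)C`, gives 9.8%.
Compound 2, `CC(C)=CCC1Cc2c(OCCCNS(=O)(=O)c3ccc(Br)cc3)cc(=O)n(CCCO)c2CC1(C)C`, gives 3.7%.
Compound 3, `COc1ccc(OCCCOc2cc(=O)n(CCCO)c3c2CC(CC=C(C)C)C(C)(C)C3)cc1`, gives 4.1%.

The three measured compounds sit close together. Compound 2 stands in this assay at a number that differs from compound 1 by a number 6.1 percentage points lower from compound 1 to compound 2 (within the scatter) and from compound 3 by a number 0.4 percentage points higher from compound 2 to compound 3 (within the scatter), both within the scatter, so the three cannot be told apart on these numbers. The step from compound 1 to compound 3, a number 5.7 percentage points lower from compound 1 to compound 3 (within the scatter), is within the scatter as well.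

Compound 4, `CC(C)=CCC/C(C)=C/CC1Cc2c(OCCCNS(=O)(=O)c3ccc(Br)cc3)cc(=O)n(CCCO)c2CC1(C)C`, differs from compound 2 in one place: 3-methylbut-2-en-1-yl in place of hydrogen on a saturated chain carbon bound to a double-bonded chain carbon. For the measured compounds named here, no measured step touches this part of the core; the measured steps only exchange the halogen or replace the sulfonamide by the aryl ether, and each of them stayed within the scatter. There is therefore no basis for expecting a step beyond the scatter in either direction, and compound 4 is expected to give 6%, between -6% and 18%. The expected step from compound 2 is a number 2.3 percentage points higher from compound 2 to compound 4 (within the scatter).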

Compound 4, a percentage reported as inhibition, at one concentration (the size of the read-out at that concentration, not a potency): 0%
The estimate for compound 4 lay 6 percentage points above the measured number, and the stated range covers the measured number.
By their numbers in this assay, from the lowest: compounds 4, 2, 3 and 1 (each within the scatter of the next).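

Compound 4 is the first of these compounds to vary the chain on the shared core rather than the halogen or the sulfonamide: the 3-methylbut-2-en-1-yl chain is extended to 3,7-dimethylocta-2,6-dien-1-yl. In this assay, this addition of 5 carbon atoms gives a number 3.7 percentage points lower from compound 2 to compound 4 (within the scatter), so compound 2 and compound 4 cannot be told apart, and this enlargement of the chain has no readable effect on the number. No available evidence bears on this result.

As far as these compounds go, it remains open whether any other group on this chain would give a step beyond the scatter, such as a terminal amine or carboxylic acid, or a chain ending in a phenyl ring. From the compounds shown here alone, it is also open whether the 3,7-dimethylocta-2,6-dien-1-yl chain would behave in the same way alongside the chloro sulfonamide or the 4-methoxyphenoxy group.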